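The source may hold more compounds than are shown below. What is called first, only, known or untested is meant among the compounds shown, and "the series" means these compounds.

In an assay on HEK293 cells for negative allosteric modulation of metabotropic glutamate receptor 5 (Homo sapiens), read by FLIPR, with a stated time of 1 h (a lower number here means a stronger inhibitor, a higher number a weaker inhibitor), two compounds sharing a common core have been measured, and a third awaits its number. For the measured compounds named here, compound 1 `COc1ccccc1C#Cc1nc2c(s1)C(=O)NCC2` differs from compound 2 in more than one place, so no single step links them. In this assay compound 1 reaches only a limit, > 10000 nM, rather than a number. Compound 2 `CCN1CCc2nc(C#Cc3ccccc3)sc2C1` carries an ethyl on its ring amine nitrogen, and in this assay compound 2 gives 1200 nM. That is the single numerical result shown; the other result sits at the limit of > 10000 nM in this assay, at which 1 of the 2 values shown sits. Going by the values given here, since no two measured compounds differ in one place, there is no measured step to calibrate an expectation.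

Compound 3 `O=C(C1CC12CCC2)N1CCc2nc(C#Cc3ccccc3)sc2C1` is the candidate. It differs from compound 2 as follows: a group of 8 heavy atoms (7 carbon, 1 oxygen; one three-membered non-aromatic ring of carbon only, one four-membered non-aromatic ring of carbon only) in place of a group of 2 heavy atoms (2 carbon; no ring), on an amine nitrogen in a ring. Among the compounds with values here, with no measured step to lean on, the expectation rests on the change alone: the step of an 8.0-fold lower number from compound 2 to compound 3 (0.90 log units; beyond the scatter) is expected to run toward stronger inhibition, beyond the usual scatter. Compound 3 is therefore estimated at 150 nM, with a plausible range from 30 nM to 800 nM.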

Compound 3, half-maximal inhibitory concentration: > 10000 nM
Compound 3: only a limit was reported; the forecaster's own chance of this, stated with the estimate: 5%; middle value at least 66-fold (1.82 log units) from the limit.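

On the amine nitrogen in the ring, the group of 8 heavy atoms with its three-membered and four-membered carbon rings does not improve on ethyl in this assay: the change gives an at least 8.3-fold higher number from compound 2 to compound 3 (0.92 log units; beyond the scatter). For the compounds shown here, this is the first measured single-place step, and it shows that inhibition depends on what this nitrogen carries, since the step lies beyond the usual scatter and runs toward weaker inhibition. Compound 3 stands at a limit of the assay and not at a number, which leaves the true size of the loss unread and places compound 3 in the same position as one other compound: the limit of > 10000 nM in this assay, at which 2 of the 3 values shown sit.

The step changes several things at once, including the size of the group, its two carbon rings and its oxygen, and the compounds shown do not separate these features from one another. On these data alone, it remains open whether a methyl, an acetyl or a benzyl on this nitrogen, or the free amine carrying only a hydrogen, would match compound 2, exceed it or also fall to the limit.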